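Series notes: methyl on the hydroxy oxygen of compound 3

The compounds below may be only part of what the source reports. "The series", "measured", "known", "first", "only" and "open" are said of these compounds alone.

Measured so far in a functional assay on PC-3 cells (Homo sapiens) for antiproliferative activity, read by MTT assay, with a stated time of 48 h; on this read-out higher numbers stand for weaker inhibition and lower numbers for stronger inhibition:
Compound 1 `COc1ccc(-c2nn(-c3ccccc3)cc2C(=O)/C=C\Nc2ccc(Cl)cc2)cc1` gives 3890 nM.
Compound 2 `COc1ccc(-c2nn(-c3ccccc3)cc2C(=O)/C=C\Nc2ccc(C(F)(F)F)cc2)cc1` gives > 50000 nM, which is a limit of the assay and not a number.
Compound 3 `COc1ccc(-c2nn(-c3ccccc3)cc2C(=O)/C=C\Nc2ccc(O)cc2)cc1` gives 1980 nM.

Compound 3 holds the lowest of the two numbers available, but its nearest neighbour is compound 1, and a 2.0-fold lower number from compound 1 to compound 3 (0.29 log units; within the scatter) lies within the scatter, so no order between these two can be claimed. The trifluoromethyl analogue stands apart: an at least 12-fold higher number from compound 1 to compound 2 (1.10 log units; beyond the scatter) and an at least 25-fold lower number from compound 2 to compound 3 (1.40 log units; beyond the scatter) are both large, and compound 2 sits at the limit of > 50000 nM in this assay, at which 1 of the 3 values shown sits.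

Compound 4 `COc1ccc(N/C=C\C(=O)c2cn(-c3ccccc3)nc2-c2ccc(OC)cc2)cc1` differs from compound 3 by methyl in place of hydrogen on an oxygen on an aromatic ring. Within the data shown here, none of the measured steps touches this place: all three exchange the group on the aromatic carbon itself, whereas here the change is on the oxygen and that carbon keeps its oxygen. The measured steps only show that chloro and hydroxy at that carbon give numbers within the scatter of each other, while trifluoromethyl gives a large rise. Among the measured compounds shown here, no step therefore bears directly on capping the oxygen with methyl, and the expectation is a step of at most modest size, if any, as a 1.5-fold higher number from compound 3 to compound 4 (0.18 log units; within the scatter). Compound 4 is estimated at 3000 nM, with a range from 900 nM to 10000 nM.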

Compound 4, half-maximal inhibitory concentration: 13400 nM
Compound 4: middle estimate off by 4.5-fold (0.65 log units), on the low side, outside the stated range (above it).
By their numbers in this assay, from the lowest: compounds 3 and 1 (each within the scatter of the next); then compound 4. At a limit, above all of these: compound 2.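

In this assay, the oxygen on the aromatic ring proves sensitive to capping: methyl in place of hydrogen gives a 6.8-fold higher number from compound 3 to compound 4 (0.83 log units; beyond the scatter), so a change that leaves the oxygen in place still shifts the number beyond the scatter. Methoxy is also separated from chloro, with a 3.4-fold higher number from compound 1 to compound 4 (0.54 log units; beyond the scatter), and from trifluoromethyl, with an at least 3.7-fold lower number from compound 2 to compound 4 (0.57 log units; beyond the scatter), so compound 4 stands apart from both the pair of compounds 1 and 3 and compound 2. Compound 2 gives a limit and not a number, so its step to compound 4 has only a lower bound: the limit of > 50000 nM in this assay, at which 1 of the 4 values shown sits.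

The compounds shown do not separate the loss of the hydrogen on the oxygen from the presence of the added methyl, and a larger group on that oxygen, such as ethyl or acetyl, would bear on this. Among these compounds, whether hydroxy and chloro are the only groups giving numbers at this level on the aromatic carbon also stays open, and an amine or a carboxylic acid there would test it.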